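Fluoro to Nitro on a Core That Shows No Activity

The compounds below may be only part of what the source reports. "The series", "measured", "known", "first", "only" and "open" are said of these compounds alone.

Of the compounds shown here, two that share one core have been tested in a functional assay on Jurkat cells (Homo sapiens) for antiproliferative activity, read by WST assay, with a stated time of 72 h; a higher number here means a weaker inhibitor, a lower number a stronger inhibitor. Compound 1 `O=[N+]([O-])c1ccc2[nH]c(-c3nc(-c4ccccc4)no3)cc2c1` carries a nitro group together with a plain phenyl ring. In this assay compound 1 gives only a limit of the assay, > 50000 nM, and no number. Compound 2 `Fc1ccc2[nH]c(-c3nc(-c4ccc(Cl)cc4)no3)cc2c1` carries a fluoro group together with a chlorophenyl ring. In this assay compound 2 likewise gives only a limit, > 50000 nM, so no number is known for it either. Where compound 2 stands is therefore plain: the limit of > 50000 nM in this assay, at which 2 of the 2 values shown sit, and nothing separates the two measured compounds. Compound 3 `O=[N+]([O-])c1ccc2[nH]c(-c3nc(-c4ccc(Cl)cc4)no3)cc2c1` has not yet been measured. It differs from compound 2 in one place: nitro in place of fluoro on an aromatic carbon. For the measured compounds named here, neither measured compound yielded a number, so no measured step can be carried over. Compound 1 already bears the nitro group and sits at the limit > 50000 nM. The step of a number no higher from compound 2 to compound 3 (the limit leaves the size open) is expected to stay within the scatter. Compound 3 is thus expected at 50000 nM in this assay, within 20000 nM to 100000 nM, and most likely it too will be reported only as a limit.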

Compound 3, half-maximal inhibitory concentration: > 50000 nM
Compound 3 was reported as a limit; the forecaster's own chance of this, stated with the estimate: 85%; the middle value lies on the limit itself.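

In this assay, for the compounds shown here, compound 3 sits at the same limit as compound 1 and compound 2, so no step to compound 3 from either of them can be read: the limit of > 50000 nM in this assay, at which 3 of the 3 values shown sit. The three compounds leave open how the nitro, fluoro and chloro groups each bear on antiproliferative activity, and whether any compound on this shared core gives an actual number rather than a limit.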